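A longer chain on compound 3: what to expect

This account rests on a few compounds, and the source may have more. Where it says the series, first, only, none or still open, it means among the compounds named here.

In a functional assay on HepG2 cells (Homo sapiens) for antiproliferative activity, read by MTT assay, with a stated time of 48 h (on this read-out lower numbers stand for stronger inhibition and higher numbers for weaker inhibition), compound 1 (`COc1ccc(N(C)c2ccnc(Cl)n2)cc1OCCCBr`) gives 1240 nM and compound 2 (`COc1ccc(N(C)c2ccnc(Cl)n2)cc1OCC[Se]C#N`) gives 1670 nM while compound 3 (`COc1ccc(N(C)c2ccnc(Cl)n2)cc1OCCC[Se]C#N`) gives 5150 nM and so has the highest number of the three. The structural change leading to compound 4 (`COc1ccc(N(C)c2ccnc(Cl)n2)cc1OCCCCC[Se]C#N`) is a group of 5 heavy atoms (3 carbon, 1 nitrogen, 1 selenium; no ring) in place of a group of 3 heavy atoms (1 carbon, 1 nitrogen, 1 selenium; no ring), on a saturated chain carbon, three bonds along the chain from an oxygen on an aromatic ring and it sits on a saturated chain carbon, three bonds along the chain from an oxygen on an aromatic ring. The chain therefore grows. The nearest guide is a 3.1-fold higher number from compound 2 to compound 3 (0.49 log units; beyond the scatter). That step also lengthens the chain, though a single step is thin evidence. The steps of a 1.3-fold higher number from compound 1 to compound 2 (0.13 log units; within the scatter) and a 4.2-fold higher number from compound 1 to compound 3 (0.62 log units; beyond the scatter) both start from a compound carrying bromine and say less about chain length alone. The expected change in this assay is a further modest rise in the number, a 2.3-fold higher number from compound 3 to compound 4 (0.37 log units; beyond the scatter) by this estimate. For compound 4 the estimated value is 12000 nM with an expected range from 4000 nM to 35000 nM as the likely span.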

Compound 4, half-maximal inhibitory concentration: > 10000 nM
Compound 4 ended at the assay's limit (the forecaster's own chance of this, stated with the estimate: 5%); the middle value lies beyond the limit too.
By their numbers in this assay, from the lowest: compounds 1 and 2 (each within the scatter of the next); then compound 3. At a limit, above all of these: compound 4.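

In this assay compound 4 gives > 10000 nM, which is a limit of the assay and not a number. The step of an at least 1.9-fold higher number from compound 3 to compound 4 (0.28 log units; that floor lies within the scatter) therefore does not by itself separate these two compounds, but an at least 5.9-fold higher number from compound 2 to compound 4 (0.77 log units; beyond the scatter) and an at least 8.0-fold higher number from compound 1 to compound 4 (0.90 log units; beyond the scatter) are both clear gaps, so the longest chain shown brings no return towards the lower numbers. The reading for this compound stops at the end of the measurable range, so its real size is hidden: the limit of > 10000 nM in this assay, at which 1 of the 4 values shown sits.

As far as these compounds go, how far past that limit compound 4 lies stays open, as does where a chain of a length between those of compound 3 and compound 4 would fall. Also open, from the compounds shown here alone, is what an amine or a carboxylic acid would give in place of this group, on the same saturated chain carbon.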